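Bromo to fluoro: notes on compound 3

The source may hold more compounds than are shown below. What is called first, only, known or untested is meant among the compounds shown, and "the series" means these compounds.

The series shares the core of compound 1 (`Cc1nc(CS(=O)(=O)c2ccccc2)c([N+](=O)[O-])n1C`), read in an ADME assay on THP-1 cells (Homo sapiens) for cytotoxicity, read by flow cytometry and propidium iodide staining, with a stated time of 72 h; on this read-out higher numbers stand for weaker inhibition and lower numbers for stronger inhibition. Compound 1 gives > 846000 nM, which is a limit of the assay. Among the measured compounds shown here, compound 2 (`Cc1nc(CS(=O)(=O)c2ccc(Br)cc2)c([N+](=O)[O-])n1C`) gives 326000 nM, the only actual number in the set so far. For the measured compounds named here, the only measured step bearing on the next change is an at least 2.5-fold lower number from compound 1 to compound 2 (0.41 log units; beyond the scatter), with bromo in place of hydrogen on an aromatic carbon. Compound 3 (`Cc1nc(CS(=O)(=O)c2ccc(F)cc2)c([N+](=O)[O-])n1C`) differs from compound 2 by fluoro in place of bromo on an aromatic carbon, para to a large group. Resting on that single step, part of the lowering is expected to be lost once the bromo leaves, although one step sets no trend. In this assay a higher number of modest size is therefore expected, possibly close to the scatter, and only a limit may come back. The expected change is a 1.8-fold higher number from compound 2 to compound 3 (0.26 log units; within the scatter). For compound 3 the estimate is 600000 nM, with an expected range of 300000 nM to 1000000 nM.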

Compound 3, half-maximal inhibitory concentration: > 797000 nM
Compound 3: only a limit was reported; the forecaster's own chance of this, stated with the estimate: 40%; middle value at least 1.3-fold (0.12 log units) away from the limit.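

In this assay, the change at this carbon, para to a large group, can now be read from the bromo side: the result is an at least 2.4-fold higher number from compound 2 to compound 3 (0.38 log units; beyond the scatter), so the lower number of compound 2 does not carry over from bromo to fluoro. Compound 3 returns only a limit, so fluoro gives no actual number here: the limit of > 797000 nM in this assay, at which 1 of the 3 values shown sits. The step from hydrogen to fluoro on this carbon cannot be read, since compound 1 is also only a limit: the limit of > 846000 nM in this assay, at which 1 of the 3 values shown sits.

Among the compounds shown here, compound 2 remains the only compound in the set with an actual number, so a single bromo compound carries everything known about lowering the number in this assay, and whether this is particular to bromo or shared by other groups on the same carbon stays open. Chloro or iodo would test this within the halogens, while a methyl, an amine or a carboxylic acid at this place would show whether any non-halogen group also gives an actual number rather than a limit.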